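From the 3-fluorophenyl to the 2-fluorophenyl compound

The compounds below may be only part of what the source reports. "The series", "measured", "known", "first", "only" and "open" are said of these compounds alone.

Measured in a functional assay on PC-3 cells (Homo sapiens) for inhibition, read by MTT assay, with a stated time of 48 h, tested at 10 uM; on this read-out higher numbers stand for more inhibition of growth at the one concentration tested and lower numbers for less inhibition of growth:
Compound 1 `CN1CC[C@H](c2c(O)cc(O)c3c(=O)cc(/C=C/c4cccc(Cl)c4)oc23)[C@H](O)C1`: 53%
Compound 2 `CN1CC[C@H](c2c(O)cc(O)c3c(=O)cc(/C=C/c4cccc(F)c4)oc23)[C@H](O)C1`: 67%

In this assay compound 2 gives 67%, the higher of the two numbers, and its gap to compound 1 lies beyond the scatter. The next compound, compound 3 `CN1CC[C@H](c2c(O)cc(O)c3c(=O)cc(/C=C/c4ccccc4F)oc23)[C@H](O)C1`, keeps the shared core and differs in one group: 2-fluorophenyl in place of 3-fluorophenyl on a double-bonded chain carbon bound to a double-bonded chain carbon. The two have the same atoms, joined differently. Among the compounds with values here, only one measured step bears on this change, and only indirectly: a number 14 percentage points higher from compound 1 to compound 2 (beyond the scatter), with fluoro in place of chloro on an aromatic carbon. Within the data shown here, that step exchanged the halogen, whereas here the fluorine remains and the group changes from 3-fluorophenyl to 2-fluorophenyl, so no measured step shows the effect of such a change directly. No step beyond the scatter is therefore expected in this assay, with only a slight expected lean downward, as compound 2 at 67% is the higher of just two numbers. The estimated change is a number 5 percentage points lower from compound 2 to compound 3 (within the scatter). For compound 3 the expected value is 62%, with an estimated range of 47% to 76%.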

Compound 3, percent growth inhibition at one concentration: 25%
Estimate against measurement, compound 3: 37 percentage points above; the whole stated range lies above it.
By their numbers in this assay, from the lowest: compound 3; then compound 1; then compound 2.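

In this assay, the result shows that this place on the shared core is sensitive to the arrangement of the aryl group even when its atoms stay the same: replacing 3-fluorophenyl with 2-fluorophenyl gives a number 42 percentage points lower from compound 2 to compound 3 (beyond the scatter). The 2-fluorophenyl group also compares poorly with 3-chlorophenyl, with a number 28 percentage points lower from compound 1 to compound 3 (beyond the scatter), and the earlier exchange of halogen, a number 14 percentage points higher from compound 1 to compound 2 (beyond the scatter), was the smaller change, so the two halogen-bearing groups that share the 3-substituted pattern both stand above the 2-fluorophenyl compound. Nothing given here accounts for this drop in growth inhibition.

The three compounds cannot show whether the low number of compound 3 belongs to fluorine specifically or to any substituent arranged as in 2-fluorophenyl, and a 2-chlorophenyl or 2-methoxyphenyl group would bear on that question. How an unsubstituted phenyl group would compare on the same double-bonded chain carbon also remains open, so the compounds shown fix neither a baseline for these halogen effects nor a trend beyond these three.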